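The source may hold more compounds than are shown below. What is called first, only, known or untested is meant among the compounds shown, and "the series" means these compounds.

Going by the values given here, in an ADME assay on CHO-K1 cells (Cricetulus griseus) for cytotoxicity, read by MTT assay, with a stated time of 24 h (a higher number here means a weaker inhibitor, a lower number a stronger inhibitor), compound 2 (`CCCCCCCC(=O)Nc1nnc(S[C@@H]2O[C@H](CO)[C@H](O)[C@H](O)[C@H]2O)s1`) gives 60100 nM, the only number so far. Among the compounds with values here, compound 1 (`CCCCCCCCCCCCCCCCCC(=O)Nc1nnc(S[C@@H]2O[C@H](CO)[C@H](O)[C@H](O)[C@H]2O)s1`) gives "not active" (no number reported), with no number reported, so no measured step is available. Compound 3 (`CCCCCCCC/C=C\CCCCCCCC(=O)Nc1nnc(S[C@@H]2O[C@H](CO)[C@H](O)[C@H](O)[C@H]2O)s1`) differs from compound 2 by dec-1-en-1-yl in place of hydrogen on a saturated chain carbon, seven bonds along the chain from a carbonyl carbon; the entering dec-1-en-1-yl has no ring. Within the data shown here, with compound 1 at "not active" (no number reported) as the only guide on longer chains, a modest move toward weaker inhibition is expected. The expected step is a 2.2-fold higher number from compound 2 to compound 3 (0.34 log units; beyond the scatter). For compound 3 the estimated value is 130000 nM, with an expected range of 40000 nM to 400000 nM.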

Compound 3, half-maximal inhibitory concentration: "not active" (no number reported)
Compound 3 has no reported number here, and the estimate cannot be compared.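

Going by these compounds alone, compound 3, like compound 1, carries no number, so no step from compound 2 can be read. The compounds shown leave open how the longer chains compare numerically with compound 2. No supporting data bear on this result.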